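A few compounds are considered here, and "the series" means these few. Any claim that something is new, unique, unknown or untested is made for them only; others in the source may bear on it.

Measured in a functional assay on A549 cells (Homo sapiens) for antiproliferative activity, with a stated time of 5 days; on this read-out higher numbers stand for weaker inhibition and lower numbers for stronger inhibition:
- compound 1 `CC1OC2(C=CC(=O)C=C2)N(c2nc(-c3cccc4ccccc34)nn2-c2ccccc2)C1=O`: 180 nM
- compound 2 `Cc1ccc(-n2nc(-c3ccc4ccccc4c3)nc2N2C(=O)COC23C=CC(=O)C=C3)cc1`: 110 nM

With only these two numbers available, compound 1 at 180 nM and compound 2 at 110 nM lie within the usual scatter of each other, so compound 1 cannot be separated from compound 2 in this assay.

Next in the series is compound 3 `O=C1C=CC2(C=C1)OCC(=O)N2c1nc(-c2cccc3ccccc23)nn1-c1ccccc1`, which has not yet been measured. Its structure departs from that of compound 1 at one place: hydrogen in place of methyl on a saturated ring carbon. This is hydrogen in place of methyl on a saturated ring carbon, next to the ring oxygen.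

Within the data shown here, no measured pair differs at one place only, so the size of this change in this assay has no direct precedent. Among the measured compounds shown here, the only guide is the closeness of compound 1 at 180 nM and compound 2 at 110 nM, and neither value points to a large effect. No step beyond the scatter is expected, and no firm direction is assumed. The expected change a 1.3-fold lower number from compound 1 to compound 3 (0.11 log units; within the scatter) is therefore small. For compound 3 the estimated value is 140 nM, with an expected range from 50 nM to 400 nM.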

Compound 3, half-maximal inhibitory concentration: 80 nM
Estimate against measurement, compound 3: 1.8-fold (0.24 log units) above, within the range that was stated.
By their numbers in this assay, from the lowest: compounds 3, 2 and 1 (each within the scatter of the next, the first and the last beyond it).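

Hydrogen in place of methyl on a saturated ring carbon, next to the ring oxygen, gives a 2.3-fold lower number from compound 1 to compound 3 (0.35 log units; beyond the scatter) in this assay, the first step in the series that can be tied to a single place. The earlier values could not show this, since compound 1 and compound 2 differ in more than one place. The new step shows that the methyl is not needed for antiproliferative activity on this core and that this position can affect the read-out, although the step is only modest. No measurement at hand explains the step, so it stands as an observation without a cause.

As far as these compounds go, one pair gives only a single size and direction at this carbon, so it remains open whether an ethyl, a hydroxymethyl or an amine at the same position would follow the methyl or the hydrogen. From the compounds shown here alone, it also remains open whether the same change would give a step of similar size on the core of compound 2.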